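The source may hold more compounds than are shown below. What is called first, only, known or untested is meant among the compounds shown, and "the series" means these compounds.

Measured in a functional assay on L1210 cells (Mus musculus) for antiproliferative activity, read by cell counting, with a stated time of 2 days; on this read-out higher numbers stand for weaker inhibition and lower numbers for stronger inhibition:
Compound 1 `COc1ccc(Nc2nc(N)c(C(=O)c3ccccc3)s2)cc1`: 850 nM
Compound 2 `COc1ccc(Nc2nc(N)c(C(=O)c3ccc(OC)c(OC)c3)s2)cc1`: 38 nM
Compound 3 `Nc1nc(Nc2ccc(Cl)cc2)sc1C(=O)c1ccccc1`: > 10000 nM, which is a limit of the assay

Compound 1 at 850 nM holds the higher of the two true numbers, and compound 2 lies well lower at 38 nM. Compound 4 `COc1ccc(Nc2nc(N)c(C(=O)c3ccc(Br)cc3)s2)cc1` keeps the core of compound 1 but turns its phenyl into 4-bromophenyl, with bromo in place of hydrogen on an aromatic carbon. Going by the values given here, the only measured single change is an at least 11-fold higher number from compound 1 to compound 3 (1.07 log units; beyond the scatter). That step was large, but it swaps a group elsewhere in the molecule, so it is a weak guide here. Compound 2 at 38 nM does differ from compound 1 on this phenyl, but through methoxy groups, not bromo. The expected step, a 1.2-fold lower number from compound 1 to compound 4 (0.08 log units; within the scatter), is therefore moderate and uncertain in direction. For compound 4 the estimated value is 700 nM, with an expected range from 120 nM to 4000 nM.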

Compound 4, half-maximal inhibitory concentration: 110 nM
For compound 4 the middle estimate is 6.4-fold (0.80 log units) above the measured one, and the stated range ends above it.
By their numbers in this assay, from the lowest: compound 2; then compound 4; then compound 1. At a limit, above all of these: compound 3.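

Until now no single change on this phenyl had been read, and here phenyl to 4-bromophenyl gives a 7.7-fold lower number from compound 1 to compound 4 (0.89 log units; beyond the scatter) in this assay. The place on an aromatic carbon, para to a large group, therefore responds to a single bromo, which adds no hydrogen-bond donors or acceptors. Nothing measured here explains why bromo changes the number in this way. Still open, as far as these compounds go, is how an amine or a carboxylic acid would fare at this same place. Also open, from the compounds shown here alone, is whether bromo on another carbon of this ring would match it.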